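The source may hold more compounds than are shown below. What is called first, only, known or untested is meant among the compounds shown, and "the series" means these compounds.

Of the compounds shown here, three have so far been measured in an assay on COS-7 cells for inhibition of patatin-like phospholipase domain-containing protein 2 (Mus musculus), tested at 200 uM; on this read-out higher numbers stand for more inhibition at the one concentration tested (going by the name of the read-out) and lower numbers for less inhibition. Compound 1 `CCOC(=O)c1cccc(-c2ccc(OCC)cc2)n1` gives 79%, compound 2 `CCOC(=O)c1cccc(-c2ccc(CN3CCCCC3)cc2)c1` gives 68%, and compound 3 `CCOC(=O)Nc1cccc(-c2ccc(N(C)C)cc2)c1` gives 93%. On these numbers compound 3 stands highest: its nearest neighbour is compound 1, whose figure is lower by an amount beyond the usual scatter, and compound 2 lies further below it, again beyond the scatter. Among the measured compounds shown here, none of the three pairs differs in only one place, so no single step has been isolated among the measured compounds.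

The next compound, compound 4 `CN(C)c1ccc(-c2cccc(NC(=O)C(C)(C)C)c2)cc1`, departs from compound 3 in one place: tert-butyl in place of ethoxy on a carbonyl carbon. The carbonyl carbon that carries the change keeps its amide-type nitrogen as its other neighbour.

For the measured compounds named here, since no measured pair shows the effect of such a change, the size of the step is uncertain. A step of modest size is expected, most likely staying within the scatter or falling slightly, so that the estimated change is a number 9 percentage points lower from compound 3 to compound 4 (within the scatter). Compound 4 is therefore expected to reach 84%, with a range from 62% to 97%.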

Compound 4, a percentage reported as inhibition, at one concentration (the size of the read-out at that concentration, not a potency): 25%
For compound 4 the middle estimate is 59 percentage points above the measured one; the measured number lies below the stated range.
By their numbers in this assay, from the lowest: compound 4; then compound 2; then compound 1; then compound 3.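

In this assay, among the compounds shown here, tert-butyl in place of ethoxy on a carbonyl carbon, with the amide-type nitrogen kept as that carbon's other neighbour, gives the first step that can be read at a single place: a number 68 percentage points lower from compound 3 to compound 4 (beyond the scatter). For the compounds shown here, the group on this carbonyl carbon therefore has a large bearing on the read-out, something the earlier compounds, which all differ in more than one place, could not show. Nothing available bears on why this step is so large.

Still open, as far as these compounds go, is whether the step follows the loss of the ethoxy oxygen or the arrival of tert-butyl itself: a methoxy, an isopropyl or a dimethylamino group on the same carbonyl carbon would separate the two. Also open, from the compounds shown here alone, is whether the step would hold at other concentrations, as the read-out reports one concentration and not a potency.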